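A smaller aromatic ring enters in place of a larger one

The source may hold more compounds than are shown below. What is called first, only, known or untested is meant among the compounds shown, and "the series" means these compounds.

Of the compounds shown here, three have been measured in a functional assay for agonist activity at growth hormone secretagogue receptor type 1 (Homo sapiens), read by FLIPR; on this read-out lower numbers stand for smaller maximal responses and higher numbers for larger maximal responses. Compound 1 `COc1ccc(NS(=O)(=O)c2ccc(-c3ccccn3)s2)cc1N1C[C@@H](C)N[C@@H](C)C1` gives 0.9 in this assay, and compound 2 `CCOc1ccc(N2C[C@@H](C)N[C@@H](C)C2)cc1NS(=O)(=O)c1ccc(-c2ccccn2)s1` gives 0.8. Compound 3 `COc1ccc(F)c(-c2ccc(S(=O)(=O)Nc3cc(N4C[C@@H](C)N[C@@H](C)C4)ccc3OC)cc2)c1` holds the highest of the three numbers with 1.2; its nearest neighbour is compound 1, lower by an amount beyond the usual scatter, and compound 2 lies further away, also beyond the scatter. The account now turns to compound 4 `COc1ccc(N2C[C@@H](C)N[C@@H](C)C2)cc1NS(=O)(=O)c1ccc(-c2cccs2)cc1`, which has not yet been measured. Against compound 3 it carries a single change: thiophen-2-yl in place of 2-fluoro-5-methoxyphenyl on an aromatic carbon. Among the compounds with values here, no pair of measured compounds differs in one place only, so no measured step speaks directly to this change. The expectation is that compound 4 keeps a full response in this assay, estimated at 1 with a range from 0.7 to 1.3, because compound 3 gives 1.2 and each measured compound reaches a response close to that of the reference agonist. The expected step is a number 0.20 lower from compound 3 to compound 4 (beyond the scatter), a modest decrease that may or may not exceed the scatter.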

Compound 4, intrinsic activity: the largest response reached, as a fraction of the reference agonist's: 1
Beside the measured number, compound 4's estimate shows no gap at the digits printed, and the stated range covers the measured number.
By their numbers in this assay, from the lowest: compounds 2, 1 and 4 (each within the scatter of the next, the first and the last beyond it); then compound 3.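

In this assay, the exchange of 2-fluoro-5-methoxyphenyl for thiophen-2-yl, on an aromatic carbon para to a large group, gives a number 0.20 lower from compound 3 to compound 4 (beyond the scatter), the first step read at this position. The step is modest: with a ring of 5 heavy atoms in place of one of 9, compound 4 still reaches 1, so a substantial maximal response at this position does not require the fluorine, the methoxy group or a six-membered ring. Nothing measured here accounts for the size of the step.

This single step changes ring size, the hetero atom and both substituents at once, so it does not show which of these carries the difference. Going by these compounds, how a plain phenyl ring or a furan-2-yl ring would behave at this position remains open.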